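Three aryloxy pyrazole oximes and an untested methylphenyl analogue

The compounds below may be only part of what the source reports. "The series", "measured", "known", "first", "only" and "open" are said of these compounds alone.

Compound 1, `CCc1nn(C)c(CO/N=C/c2c(C)nn(C)c2Oc2ccc(Cl)cc2)c1Cl`, in a functional assay on SMMC-7721 cells (Homo sapiens) for inhibition, read by MTT assay, with a stated time of 72 h, tested at 25 uM (a lower number here means less inhibition, a higher number more inhibition at the concentration tested (going by the name of the read-out)), gives < 80%, which is a limit of the assay and not a number.
Compound 2, `CCc1nn(C)c(CO/N=C/c2c(C)nn(C)c2Oc2ccccc2Cl)c1Cl`, in this assay gives < 80%, again a limit rather than a number.
Compound 3, `CCc1nn(C)c(CO/N=C/c2c(C)nn(C)c2Oc2ccc(I)cc2)c1Cl`, in this assay gives < 80%, also a limit and not a number.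

For the measured compounds named here, compound 3 therefore stands at the same limit as every other measured compound, as the limit of < 80% in this assay, at which 3 of the 3 values shown sit, shows; no measured step is readable: a step that the two limits leave unreadable from compound 1 to compound 2, a step that the two limits leave unreadable from compound 1 to compound 3 and a step that the two limits leave unreadable from compound 2 to compound 3 all stay hidden behind the limits. Compound 4, `CCc1nn(C)c(CO/N=C/c2c(C)nn(C)c2Oc2cccc(C)c2)c1Cl`, has not been measured. It differs from compound 3 by 3-methylphenyl in place of 4-iodophenyl on an oxygen on an aromatic ring. Since the earlier swaps of the aryl group on the oxygen left every value at the limit, the change to 3-methylphenyl is expected to give a step that the limit leaves unreadable from compound 3 to compound 4, that is, nothing readable beyond the scatter. Compound 4 is estimated to give 35%, with a range from 5% to 79%, most likely reported as a limit again.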

Compound 4, a percentage reported as inhibition, at one concentration (the size of the read-out at that concentration, not a potency): < 80%
Compound 4: only a limit was reported; the forecaster's own chance of this, stated with the estimate: 85%; the middle value does not contradict the limit.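

In this assay compound 4 gives < 80% as a limit and not a number. Its steps from compound 1, compound 2 and compound 3 therefore cannot be read: the limit of < 80% in this assay, at which 4 of the 4 values shown sit.
The compounds shown leave open how much inhibition each gives, and whether changing the aryl group on the oxygen alters it at all.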